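Series notes: benzylamino variation on a shared core

The compounds below may be only part of what the source reports. "The series", "measured", "known", "first", "only" and "open" are said of these compounds alone.

Measured so far in an assay on CHO cells for binding affinity to corticotropin-releasing factor receptor 1 (Homo sapiens); on this read-out higher numbers stand for weaker inhibition and lower numbers for stronger inhibition:
compound 1 `CCC(COC)Nc1cc(C)nc2c(-c3cnc(N(C)C)cc3C)c(C)nn12` gives 260 nM
compound 2 `CCCCN(CC)c1cc(C)nc2c(-c3cnc(N(C)C)cc3C)c(C)nn12` gives 2.6 nM
compound 3 `CCN(Cc1cccc(C)c1)c1cc(C)nc2c(-c3cnc(N(C)C)cc3C)c(C)nn12` gives 2.4 nM

Compound 3 holds the lowest number of the three, though compound 2 sits within the scatter of it, so no order between those two can be read; compound 1 stands far above both.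

Compound 4 is `CCN(Cc1ccc(Cl)cc1)c1cc(C)nc2c(-c3cnc(N(C)C)cc3C)c(C)nn12`. It differs from compound 3 by 4-chlorophenyl in place of 3-methylphenyl on a saturated chain carbon bound to a nitrogen on an aromatic ring.

Two steps are known. The large one, a 100-fold lower number from compound 1 to compound 2 (2.00 log units; beyond the scatter), concerns the amine substitution pattern and does not bear on the present change. The other, a 1.1-fold lower number from compound 2 to compound 3 (0.03 log units; within the scatter), swaps a chain for the ring that is now being varied and stays within the scatter, which suggests this position tolerates variation. Within the data shown here, no step varies the substituent on that ring, so the expectation rests on that tolerance alone. For compound 4 a step of a 1.3-fold higher number from compound 3 to compound 4 (0.10 log units; within the scatter) is expected, with no change beyond the scatter. Compound 4 is therefore estimated at 3 nM, in the range 1 nM to 10 nM.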

Compound 4, inhibition constant: 1.3 nM
For compound 4 the middle estimate is 2.3-fold (0.36 log units) above the measured one; the range from low to high includes it.
By their numbers in this assay, from the lowest: compounds 4, 3 and 2 (each within the scatter of the next); then compound 1.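

In this assay the exchange of 3-methylphenyl for 4-chlorophenyl gives a 1.8-fold lower number from compound 3 to compound 4 (0.27 log units; within the scatter) and the exchange of propyl for 4-chlorophenyl gives a 2.0-fold lower number from compound 2 to compound 4 (0.30 log units; within the scatter) so compounds 2, 3 and 4 cannot be ordered on this read-out. The tolerance seen earlier for a single ring group at this saturated chain carbon now also covers a ring carrying chlorine instead of methyl, with the substituent's number on the ring changed as well. No supporting data bear on this result.

The shown compounds change the substituent and its number together, so 3-chlorophenyl and 4-methylphenyl would be needed to separate the two. On these data alone, whether the tolerance extends to a ring bearing an amine or a carboxylic acid remains open.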